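The source may hold more compounds than are shown below. What is called first, only, known or untested is meant among the compounds shown, and "the series" means these compounds.

Measured compounds:
- Compound 1, `COc1ccc(C2=NN(c3ccccc3)C(c3ccc(C)cc3)C2S(=O)(=O)CC2=NCCO2)cc1`: 64.9%
- Compound 2, `COc1ccc(C2=NN(c3ccccc3)C(c3ccc(C)cc3)C2S(=O)(=O)CC2=NCCS2)cc1`: 44.9%
- Compound 3, `COc1ccc(C2=NOC(c3ccc(C)cc3)C2S(=O)(=O)CC2=NCCO2)cc1`: 65.9%

In a functional assay, read by Griess assay, with a stated time of 150 min, tested at 75 ug/mL (on this read-out lower numbers stand for a weaker effect and higher numbers for a stronger effect at the one concentration tested), compound 1 gives 64.9% and compound 2 gives 44.9%. These two share a core and differ in one place: a group of 5 heavy atoms (3 carbon, 1 nitrogen, 1 sulfur; one five-membered non-aromatic ring with 2 hetero atoms) in place of a group of 5 heavy atoms (3 carbon, 1 nitrogen, 1 oxygen; one five-membered non-aromatic ring with 2 hetero atoms), on a saturated chain carbon bound to a sulfonyl sulfur. This change made the step of a number 20 percentage points lower from compound 1 to compound 2 (beyond the scatter), a drop that lies beyond the usual scatter of the measurement.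

Compound 3 has a different core from compound 1; the difference between the two cores is not broken down here. In this assay compound 3 gives 65.9%, which is within the scatter of the number for compound 1, so the two cores read alike at this concentration.

Compound 4, `COc1ccc(C2=NOC(c3ccc(C)cc3)C2S(=O)(=O)CC2=NCCS2)cc1`, has not yet been measured. It stands to compound 3 exactly as compound 2 stands to compound 1: a group of 5 heavy atoms (3 carbon, 1 nitrogen, 1 sulfur; one five-membered non-aromatic ring with 2 hetero atoms) in place of a group of 5 heavy atoms (3 carbon, 1 nitrogen, 1 oxygen; one five-membered non-aromatic ring with 2 hetero atoms), on a saturated chain carbon bound to a sulfonyl sulfur. Among the compounds with values here, because the only measured example of this change is the step of a number 20 percentage points lower from compound 1 to compound 2 (beyond the scatter), and because compound 3 starts from 65.9%, close to the starting point of that step, the same change is expected to cost compound 4 a similar amount, so the expected step is a number 19.9 percentage points lower from compound 3 to compound 4 (beyond the scatter). A single earlier example is a thin basis, and the cores differ, so the expectation is held loosely.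

On that basis compound 4 is estimated at 46% in this assay, with a likely range from 32% to 60%.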

Compound 4, a percentage reported as activity, at one concentration (the size of the read-out at that concentration, not a potency): 54.1%
Estimate against measurement, compound 4: 8.1 percentage points below, within the range that was stated.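

In this assay, putting the sulfur-containing five-membered ring in place of the oxygen-containing one gives a number 11.8 percentage points lower from compound 3 to compound 4 (beyond the scatter) and so lowers the number on this second core as well. Set beside the earlier case, the two steps run in the same direction, and their sizes cannot be told apart: the same change on two cores in this assay, a number 20 percentage points lower (beyond the scatter) from compound 1 to compound 2 and a number 11.8 percentage points lower (beyond the scatter) from compound 3 to compound 4, 8.2 percentage points apart, within the scatter of two such steps.

This means that, on the two cores shown, the oxygen-containing ring reads higher than the sulfur-containing one, and the earlier step was a fair guide to the direction of the new one, but these two pairs cannot show that the change would behave the same way on any other core, nor do they explain why the number falls.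

The compounds shown leave open how other groups would read on the saturated chain carbon bound to a sulfonyl sulfur, for example an amine, a carboxylic acid or a longer chain in place of either five-membered ring. They also leave open whether the gap between the two rings would look the same at other concentrations, as each number here is a single reading at one concentration and not a potency.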